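Chloro to hydrogen from compound 3

This account rests on a few compounds, and the source may have more. Where it says the series, first, only, none or still open, it means among the compounds named here.

Growth inhibition data for this series are sparse, and most entries in a functional assay on U-251 cells (Homo sapiens) for inhibition, read by sulforhodamine B assay, with a stated time of 48 h (on this read-out lower numbers stand for stronger inhibition of growth and higher numbers for weaker inhibition of growth), are limits rather than numbers. Compound 1 (`CCOC(=O)c1nn(-c2ccc(Cl)cc2)c(-c2ccccc2)c1CNC(C)(C)C`) gives > 608000 nM; > 559000 nM (2 entries), and both entries are limits of this assay. Compound 2 (`CC(C)(C)NCc1c(C(=O)O)nn(-c2ccccc2)c1-c1ccccc1`) gives > 716000 nM, which is also a limit of this assay. Within the data shown here, compound 3 (`CC(C)(C)NCc1c(C(=O)O)nn(-c2ccc(Cl)cc2)c1-c1ccc(Cl)cc1`) gives 518000 nM, the only actual number among the three measured compounds.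

Compound 4 (`CC(C)(C)NCc1c(C(=O)O)nn(-c2ccc(Cl)cc2)c1-c1ccccc1`) has not yet been measured. It differs from compound 3 by hydrogen in place of chloro on an aromatic carbon, para to a large group, a change from 4-chlorophenyl to phenyl: hydrogen in place of chloro on an aromatic carbon.

Among the measured compounds shown here, no measured pair shows this change directly. The a 1.2-fold higher number from compound 3 to compound 4 (0.09 log units; within the scatter) is expected to be small, toward weaker inhibition of growth, and close to the scatter. A report of compound 4 as a limit alone would not be surprising. For compound 4 the estimated value is 640000 nM, with an expected range of 400000 nM to 800000 nM.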

Compound 4, concentration for 50% growth inhibition: > 652000 nM
Compound 4 ended at the assay's limit; the forecaster's own chance of this, stated with the estimate: 60%; middle value at least 1.0-fold (0.00 log units) from the limit.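

In this assay compound 4 gives > 652000 nM as a limit of the assay and not a number. The only direct reading of the change from 4-chlorophenyl to phenyl, on an aromatic carbon para to a large group, is an at least 1.2-fold higher number from compound 3 to compound 4 (0.09 log units; that floor lies within the scatter) and it gives a floor rather than a size, so the loss of this chloro is not shown to matter beyond the scatter. Among these compounds, compound 2 and compound 4 both stand as limits, and the step between them cannot be read, which leaves compound 3 as the only compound with an actual number.

From the compounds shown here alone, the true size of the step from chloro to hydrogen remains open. Also open, going by these compounds, is whether a methoxy group or an amine at this place would give a value clear of the assay's limit.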